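The source may report more compounds than this note shows. Statements on the series, on what has been measured and on what is new or still open speak of the compounds shown alone.

Three analogues sharing one core have been measured in a functional assay on HCT-116 cells (Homo sapiens) for antiproliferative activity, read by MTT assay, with a stated time of 72 h; a higher number here means a weaker inhibitor, a lower number a stronger inhibitor. Compound 1 `CN(C(=O)c1ccc(F)cc1)c1ccc2[nH]c(-c3n[nH]c4ccccc34)cc2n1` gives 9270 nM. Compound 2 `COc1ccc(S(=O)(=O)N(C)c2ccc3[nH]c(-c4n[nH]c5ccccc45)cc3n2)cc1` gives 22400 nM, and compound 3 `COc1ccc(OC)c(S(=O)(=O)N(C)c2ccc3[nH]c(-c4n[nH]c5ccccc45)cc3n2)c1` gives 8400 nM. Compound 1 thus stands second highest of the three: its gap to compound 3 lies within the scatter, while its gap to compound 2 lies beyond it. Within the data shown here, the only step between measured compounds, a 2.7-fold lower number from compound 2 to compound 3 (0.43 log units; beyond the scatter), concerns a 2,5-dimethoxyphenyl in place of 4-methoxyphenyl on a sulfonyl sulfur and does not touch the carbonyl carbon. Compound 4 `CN(C(=O)Nc1ccccc1)c1ccc2[nH]c(-c3n[nH]c4ccccc34)cc2n1` differs from compound 1 by anilino in place of 4-fluorophenyl on a carbonyl carbon. Among the measured compounds shown here, no measured step bears on this change, so no step beyond the scatter is expected, a 1.0-fold lower number from compound 1 to compound 4 (0.01 log units; within the scatter). Compound 4 is therefore estimated at 9000 nM, within 3000 nM to 30000 nM.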

Compound 4, half-maximal inhibitory concentration: 1.3 nM
Compound 4: the middle estimate sits 6900-fold (3.84 log units) above what was measured; measured number outside the range, below it.
By their numbers in this assay, from the lowest: compound 4; then compounds 3 and 1 (each within the scatter of the next); then compound 2.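

In this assay, anilino in place of 4-fluorophenyl on a carbonyl carbon gives a 7100-fold lower number from compound 1 to compound 4 (3.85 log units; beyond the scatter), so this position, untouched by the earlier step, responds very strongly to the group it carries. The change keeps a six-membered aromatic ring of carbon only, while the entering anilino brings a hydrogen-bond donor and the fluorine leaves. Nothing available explains the size of this step.

As far as these compounds go, whether the anilino nitrogen or the loss of fluorine matters more remains open. A 4-fluoroanilino group on this carbonyl carbon would help separate the two.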